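From Isopropylamide to Pentan-3-yl Ester on a Thiophene Core

A few compounds are considered here, and "the series" means these few. Any claim that something is new, unique, unknown or untested is made for them only; others in the source may bear on it.

Of the compounds shown here, three sharing one core have been measured in an assay on membranes from HEK293 cells for displacement of a labelled ligand from adenosine receptor A2b (Homo sapiens), read by scintillation counting, with a stated time of 30 min, tested at 1 uM; a lower number here means less inhibition, a higher number more inhibition at the concentration tested (going by the name of the read-out). Compound 1 `CC1=C(C(=O)OCc2ccccc2)C(c2ccsc2)NC(=O)N1`, a benzyl ester, gives 44% in this assay. Compound 2 `CC1=C(C(=O)NC(C)C)C(c2ccco2)NC(=O)N1`, an isopropylamide bearing furan-2-yl, gives 2%, and compound 3 `CC1=C(C(=O)NC(C)C)C(c2ccsc2)NC(=O)N1`, the matching isopropylamide bearing thiophen-3-yl, gives 3%. Going by the values given here, compound 3 stands second among the three numbers: the single step recorded, a number 1 percentage points higher from compound 2 to compound 3 (within the scatter), lies within the scatter, whereas compound 1 sits well beyond it.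

Compound 4 `CCC(CC)OC(=O)C1=C(C)NC(=O)NC1c1ccsc1` is the next member to be measured. It differs from compound 3 in one place: (pentan-3-yl)oxy in place of isopropylamino on a carbonyl carbon. Among the compounds with values here, no recorded step covers an exchange of this kind; the ring swap from compound 2 to compound 3 does not touch the carbonyl carbon. Within the data shown here, the only guide is what the two values of compound 1 and compound 3 show, an ester beside an amide on the same thiophen-3-yl core, with the ester far higher. On that basis a rise in this assay is expected for compound 4, of roughly a number 25 percentage points higher from compound 3 to compound 4 (beyond the scatter), though the pentan-3-yl group is not benzyl and the guide is a single pair. Compound 4 is therefore estimated at 28%, within a range from 5% to 55%.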

Compound 4, a percentage reported as inhibition, at one concentration (the size of the read-out at that concentration, not a potency): 26%
The estimate for compound 4 lay 2 percentage points above the measured number, and the stated range covers the measured number.
By their numbers in this assay, from the lowest: compounds 2 and 3 (each within the scatter of the next); then compound 4; then compound 1.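

Going by these compounds alone, with the shared core held, (pentan-3-yl)oxy in place of isopropylamino on a carbonyl carbon gives a number 23 percentage points higher from compound 3 to compound 4 (beyond the scatter) in this assay, the first change at this position that can be read in one place, whereas the only earlier step changed the ring group and stayed within the scatter. The exchange alters the atom bound to the carbonyl carbon and the group carried on it at once, and this single step cannot divide the rise between the two. Among the esters, pentan-3-yl in place of benzyl on an oxygen next to a carbonyl group gives a number 18 percentage points lower from compound 1 to compound 4 (beyond the scatter), which shows that the group on the oxygen also moves the number beyond the scatter. Nothing at hand bears on why either number moves.

An isopropyl ester or a pentan-3-yl amide on the shared core would separate the contribution of the oxygen from that of the chain. Also open, going by these compounds, is how a carboxylic acid, an ethyl ester or a furan-2-yl counterpart of the esters would read here.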